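The source may report more compounds than this note shows. Statements on the series, on what has been measured and on what is new or still open speak of the compounds shown alone.

Measured so far in an ADME assay on J774 cells (Mus musculus) for antiproliferative activity, with a stated time of 72 h; a lower number here means that less compound is needed, a higher number that more compound is needed for the effect:
Compound 1 `CCc1c(C)[nH]c2cc(OCOC)c(Cl)cc2c1=O`: 19000 nM
Compound 2 `CCCCc1cc2c(=O)c(-c3ccncc3)c(C)[nH]c2cc1OCCOc1ccccc1`: 23000 nM
Compound 3 `CCCCc1cc2c(=O)c(-c3ccc(OC(F)(F)F)cc3)c(C)[nH]c2cc1OCCOc1ccccc1`: 20000 nM

Compound 3 lies within the scatter of both compound 1 and compound 2. Compound 4 `CCCCc1cc2c(=O)c(-c3c(C)noc3C)c(C)[nH]c2cc1OCCOc1ccccc1` carries 3,5-dimethyl-1,2-oxazol-4-yl in place of the 4-(trifluoromethoxy)phenyl of compound 3 on an aromatic carbon: 3,5-dimethyl-1,2-oxazol-4-yl in place of 4-(trifluoromethoxy)phenyl on an aromatic carbon. Among the compounds with values here, one measured step bears on this place: a 1.2-fold lower number from compound 2 to compound 3 (0.06 log units; within the scatter), within the scatter. This is thin evidence, as no five-membered ring has been measured at this place. No step beyond the scatter is therefore expected in this assay. The expected change is no change at the digits printed from compound 3 to compound 4 (within the scatter). For compound 4 the estimated value is 20000 nM, with an expected range of 9000 nM to 40000 nM.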

Compound 4, half-maximal effective concentration: 22000 nM
Compound 4: middle estimate off by 1.1-fold (0.04 log units), on the low side; the measured number falls inside the stated range.
By their numbers in this assay, from the lowest: compounds 1, 3, 4 and 2 (each within the scatter of the next).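

In this assay, a five-membered ring at this aromatic carbon reads the same, within the scatter, as either six-membered ring (a 1.1-fold higher number from compound 3 to compound 4 (0.04 log units; within the scatter); a 1.0-fold lower number from compound 2 to compound 4 (0.02 log units; within the scatter)). Across pyridin-4-yl, 4-(trifluoromethoxy)phenyl and 3,5-dimethyl-1,2-oxazol-4-yl, neither ring size nor the hetero atoms separate the compounds at this place. No supporting measurement accounts for this flat reading. On these data alone, whether an amine or a carboxylic acid on this carbon would give a step beyond the scatter stays open. So does whether a change elsewhere on the shared core would.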